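The compounds below may be only part of what the source reports. "The series", "measured", "known", "first", "only" and "open" are said of these compounds alone.

Measured so far:
compound 1, `CC1=C(C(=O)Nc2ccc(Cl)c(Cl)c2)C(c2cccc(O)c2)NC(=S)N1`, 13500 nM
compound 2, `CC1=C(C(=O)Nc2ccc(F)c(Cl)c2)C(c2cccc(Cl)c2)NC(=S)N1`, 32400 nM
compound 3, `CC1=C(C(=O)Nc2ccc(F)c(Cl)c2)C(c2cccc(Oc3ccccc3)c2)NC(=S)N1`, 20900 nM

All three were tested in a functional assay on HOP-92 cells (Homo sapiens) for cytotoxicity, read by sulforhodamine B assay, with a stated time of 48 h; a lower number here means a stronger inhibitor of growth, a higher number a weaker inhibitor of growth. Compound 3 stands between compound 1 and compound 2 on the numbers, but every gap among the three lies within the usual scatter of the assay, so none of them can be separated from the others with any confidence.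

Compound 4, `CC1=C(C(=O)Nc2ccc(Cl)c(Cl)c2)C(c2cccc(Oc3ccccc3)c2)NC(=S)N1`, differs from compound 3 in one place: chloro in place of fluoro on an aromatic carbon. Among the measured compounds shown here, the only step measured so far is a 1.6-fold lower number from compound 2 to compound 3 (0.19 log units; within the scatter), which concerns a different group on a different ring and does not bear directly on this change. For the measured compounds named here, compound 1 carries the same 3,4-dichlorophenyl group that compound 4 will carry, but it differs from compound 3 in two places, so its value and that of compound 3 show only that the two numbers are within the scatter of each other. Nothing in these data shows that swapping fluoro for chloro at this position moves the number beyond the scatter.

Compound 4 is therefore expected to land close to compound 3, at an estimated 18000 nM, with a likely range from 8000 nM to 40000 nM. The step from compound 3 to compound 4 is expected to be a 1.2-fold lower number from compound 3 to compound 4 (0.06 log units; within the scatter), within the scatter in either direction.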

Compound 4, concentration for 50% growth inhibition: 13200 nM
Estimate against measurement, compound 4: 1.4-fold (0.13 log units) above; low and high end bracket the measured number.
By their numbers in this assay, from the lowest: compounds 4, 1, 3 and 2 (each within the scatter of the next, the first and the last beyond it).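

In this assay, among the compounds shown here, chloro in place of fluoro on an aromatic carbon, para to a large group and ortho to a chloro group, gives a 1.6-fold lower number from compound 3 to compound 4 (0.20 log units; within the scatter), so the change from 3-chloro-4-fluorophenyl to 3,4-dichlorophenyl, now read directly for the first time, cannot be told from no change at this position. For the compounds shown here, with the 3,4-dichlorophenyl group held constant, phenyl in place of hydrogen on an oxygen on an aromatic ring gives a 1.0-fold lower number from compound 1 to compound 4 (0.01 log units; within the scatter), which adds a first single-place reading on the other aromatic ring and likewise separates nothing, so every single change measured so far stays within the scatter. No measurement at hand offers an explanation for either result.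

The compounds shown leave open whether a group of another kind at this position, such as a methoxy group, a nitrile or an amine, would move the number beyond the scatter. They also leave open whether a carboxylic acid or a longer chain on the oxygen of the other aromatic ring would separate from the phenyl group found in compound 4.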